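Chain length step from compound 2 to compound 3: working notes

The source may report more compounds than this note shows. Statements on the series, on what has been measured and on what is new or still open speak of the compounds shown alone.

Measured so far:
compound 1 `CCOC(=O)c1c(-c2ccc(OC)cc2)oc2ccc(OCCCCN3C(=O)C(=O)c4cc(OC)ccc43)cc12` — 64000 nM
compound 2 `CCOC(=O)c1c(-c2ccc(OC)cc2)oc2ccc(OCCCN3C(=O)C(=O)c4ccccc43)cc12` — 64000 nM

In an ADME assay on Vero cells (Chlorocebus sabaeus) for cytotoxicity, read by MTT assay, with a stated time of 72 h (on this read-out higher numbers stand for lower toxicity in this test and lower numbers for higher toxicity in this test), compound 1 gives 64000 nM. In this assay compound 2 gives 64000 nM. Compound 2 stands level with compound 1 at the digits recorded; the two values lie within the scatter of each other, so no order between them can be read. For the measured compounds named here, no step between two measured compounds that differ in one place alone is available, so the set carries no measured direction for any single change.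

Compound 3 `CCOC(=O)c1c(-c2ccc(OC)cc2)oc2ccc(OCCCCN3C(=O)C(=O)c4ccccc43)cc12` is the chain-lengthened counterpart of compound 2: a group of 12 heavy atoms (9 carbon, 1 nitrogen, 2 oxygen; one five-membered non-aromatic ring with 1 hetero atom, one six-membered aromatic ring of carbon only) in place of a group of 11 heavy atoms (8 carbon, 1 nitrogen, 2 oxygen; one five-membered non-aromatic ring with 1 hetero atom, one six-membered aromatic ring of carbon only), on a saturated chain carbon, three bonds along the chain from an oxygen on an aromatic ring. Compound 1 and compound 2 differ in more than one place and show level values. Nothing in the set points either way, so the step of no change at the digits printed from compound 2 to compound 3 (within the scatter) is expected to be none beyond the scatter. Compound 3 is therefore estimated at 64000 nM, with a range of 32000 nM to 128000 nM.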

Compound 3, half-maximal cytotoxic concentration: > 1020000 nM
Compound 3 ended at the assay's limit (the forecaster's own chance of this, stated with the estimate: 35%); middle value at least 15-fold (1.20 log units) away from the limit.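

In this assay, the group of 12 heavy atoms in place of the group of 11 heavy atoms, on a saturated chain carbon, three bonds along the chain from an oxygen on an aromatic ring, gives an at least 15-fold higher number from compound 2 to compound 3 (1.20 log units; beyond the scatter), the first measured direction for a change at this place. Hydrogen in place of methoxy on an aromatic carbon gives an at least 15-fold higher number from compound 1 to compound 3 (1.20 log units; beyond the scatter), so a single change on the other side of the molecule also reaches beyond the scatter. The value of compound 3 is a limit of the assay, not a number: the limit of > 1020000 nM in this assay, at which 1 of the 3 values shown sits.

On these data alone, both steps end on compound 3, so their full size stays open. As far as these compounds go, how a longer chain, or an amine or a carboxylic acid on that aromatic carbon, would read in this assay also stays open.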